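The compounds below may be only part of what the source reports. "The series", "measured", "known", "first", "only" and "open" are said of these compounds alone.

Measured so far:
compound 1 `COc1ccc(-c2cc(=O)c3c(OC)cc(OC)cc3n2S(=O)(=O)c2ccc(C=O)cc2)cc1` in a functional assay on KOPN-8 cells (Homo sapiens) for antiproliferative activity, with a stated time of 72 h (a higher number here means that more compound is needed for the effect, a lower number that less compound is needed), gives > 34400 nM
compound 2 `COc1ccc(-c2cc(=O)c3c(OC)cc(OC)cc3n2S(=O)(=O)c2ccc(C)c([N+](=O)[O-])c2)cc1` in this assay gives > 51700 nM
compound 3 `COc1ccc(-c2cc(=O)c3c(OC)cc(OC)cc3n2S(=O)(=O)c2ccc(C#N)cc2)cc1` in this assay gives > 17200 nM

Each of these three values is a limit of this assay, not a number. Compound 1 sits at the limit of > 34400 nM in this assay, at which 1 of the 3 values shown sits. Compound 2 sits at the limit of > 51700 nM in this assay, at which 1 of the 3 values shown sits. Compound 3 sits at the limit of > 17200 nM in this assay, at which 1 of the 3 values shown sits. None of the three compounds is therefore placed against the others; the steps a step that the two limits leave unreadable from compound 1 to compound 3 and a step that the two limits leave unreadable from compound 2 to compound 3 both lead into compound 3 from a limit to a limit, and the step that the two limits leave unreadable from compound 1 to compound 2 is of the same kind.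

Compound 4 `COc1ccc(-c2cc(=O)c3c(OC)cc(OC)cc3n2S(=O)(=O)c2ccc(C)cc2)cc1` is not yet measured. It differs from compound 3 by methyl in place of cyano on an aromatic carbon. The steps bearing on this change, from compound 1 and from compound 2 to compound 3, are unreadable in size, so no direction can be drawn from them. Compound 4 is expected to sit again at a limit in this assay; the estimate is 40000 nM, between 10000 nM and 120000 nM. The estimated step that the limit leaves unreadable from compound 3 to compound 4 is expected to show nothing beyond the scatter.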

Compound 4, half-maximal effective concentration: > 44800 nM
Compound 4: only a limit was reported (the forecaster's own chance of this, stated with the estimate: 85%); middle value at least 1.1-fold (0.04 log units) away from the limit.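

In this assay compound 4 gives > 44800 nM, which is a limit. The steps from compound 1, compound 2 and compound 3 to compound 4 therefore cannot be read. From the compounds shown here alone, whether these four compounds differ at all in this assay remains open.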